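The compounds below may be only part of what the source reports. "The series", "measured", "known", "first", "only" and "open" are said of these compounds alone.

Compound 1 `CN1C(=O)C(F)(F)C[C@H]1C(=O)NCc1cccc(C(F)(F)F)c1Cl` gives 3.98 nM in a functional assay on HEK293 cells for antagonist activity at P2X purinoceptor 7 (Homo sapiens); on this read-out higher numbers stand for weaker inhibition and lower numbers for stronger inhibition. Compound 2 `CN1CCC(N2C[C@@H](C(=O)NCc3cccc(C(F)(F)F)c3Cl)N(C)C2=O)CC1` gives 31.6 nM in this assay.

Among the measured compounds shown here, of the two measured compounds, compound 2 stands at the higher number in this assay; the only neighbour, compound 1, shows a lower number, and that gap lies beyond the usual scatter. Compound 3 `CN1C(=O)N(c2cn(C)cn2)C[C@H]1C(=O)NCc1cccc(C(F)(F)F)c1Cl` has not been measured. It differs from compound 2 in one place: 1-methyl-1H-imidazol-4-yl in place of 1-methylpiperidin-4-yl on an amide-type nitrogen in a ring. The shared core and the amide-linked aryl part are unchanged. For the measured compounds named here, no pair of measured compounds differs by this kind of change, so the size and direction of the step in this assay cannot be read from the two numbers at hand; a step of modest size, in either direction, or none beyond the scatter is expected. Compound 3 is expected to give about 20 nM, with a range from 5 nM to 80 nM. That expectation amounts to an estimated step of a 1.6-fold lower number from compound 2 to compound 3 (0.20 log units; within the scatter).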

Compound 3, half-maximal inhibitory concentration: 2.51 nM
For compound 3 the middle estimate is 8.0-fold (0.90 log units) above the measured one; the measured number lies below the stated range.
By their numbers in this assay, from the lowest: compounds 3 and 1 (each within the scatter of the next); then compound 2.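

Putting 1-methyl-1H-imidazol-4-yl in place of 1-methylpiperidin-4-yl on the amide-type nitrogen in a ring gives a 13-fold lower number from compound 2 to compound 3 (1.10 log units; beyond the scatter) in this assay, so this position is not indifferent to the group it carries, even with the shared core and the amide-linked aryl part unchanged. The change replaces a six-membered non-aromatic ring with 1 hetero atom by a five-membered aromatic ring with 2 hetero atoms, and this single step cannot separate ring size, aromaticity and the extra nitrogen. Nothing at hand offers a reason for the size of the step.

Going by these compounds, it remains open whether a phenyl or pyridyl ring at this position would give a similarly low number. On these data alone, it also remains open whether the imidazole needs its methyl group.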